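The source may hold more compounds than are shown below. What is called first, only, known or untested is meant among the compounds shown, and "the series" means these compounds.

The measured compounds in a functional assay on HUVEC cells (Homo sapiens) for cytotoxicity, read by WST assay, with a stated time of 48 h (on this read-out lower numbers stand for stronger inhibition and higher numbers for weaker inhibition), are these. Compound 1 `O=C(NC(=S)Nc1cccc(-c2nc3ccccc3[nH]2)c1)c1ccccc1` gives > 10000 nM, which is a limit of the assay and not a number. Compound 2 `O=C(NC(=S)Nc1cccc(-c2nc3ccccc3[nH]2)c1)c1ccc2c(c1)OCCO2` gives 50 nM. Compound 3 `COc1ccc(C(=O)NC(=S)Nc2cccc(-c3nc4ccccc4[nH]3)c2)cc1OC` gives 6000 nM.

Compound 1 therefore stands at the limit of > 10000 nM in this assay, at which 1 of the 3 values shown sits, so only a ceiling is known for it and its true number may lie anywhere beyond that ceiling. Compound 4 `Cc1ccc(-c2nc3ccccc3[nH]2)cc1NC(=S)NC(=O)c1ccccc1` differs from compound 1 by methyl in place of hydrogen on an aromatic carbon. The steps measured so far all alter the aryl group on the carbonyl carbon: an at least 200-fold lower number from compound 1 to compound 2 (2.30 log units; beyond the scatter), an at least 1.6-fold lower number from compound 1 to compound 3 (0.22 log units; that floor lies within the scatter) and a 120-fold higher number from compound 2 to compound 3 (2.08 log units; beyond the scatter). Among the compounds with values here, none of them touches the ring that carries the benzimidazole and the thiourea nitrogen, which is where the methyl of compound 4 enters, so no measured step bears directly on this change. With compound 1 itself known only as a limit, there is no footing for expecting a shift beyond the scatter in this assay in either direction. Compound 4 is therefore expected to stay near the limit, with an estimated step that the limit leaves unreadable from compound 1 to compound 4. The estimate for compound 4 in this assay is 12000 nM, within a range from 3000 nM to 50000 nM, and the assay is expected more often than not to report only a limit for it.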

Compound 4, half-maximal inhibitory concentration: > 10000 nM
Compound 4 ended at the assay's limit; the forecaster's own chance of this, stated with the estimate: 60%; the middle value does not contradict the limit.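

In this assay compound 4 gives > 10000 nM, which is a limit of the assay and not a number. Compound 1 also stands at a limit, so no step can be read between compound 1 and compound 4: the limit of > 10000 nM in this assay, at which 2 of the 4 values shown sit.

The compounds shown leave open what methyl in place of hydrogen does to the number, on this core or on a compound with a measured value such as compound 2.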